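Replacing 4-methoxyphenyl with 3,4-dichlorophenyl in compound 2

A few compounds are considered here, and "the series" means these few. Any claim that something is new, unique, unknown or untested is made for them only; others in the source may bear on it.

Measured in a functional assay on MCF7 cells (Homo sapiens) for antiproliferative activity, read by MTT assay, with a stated time of 72 h; a lower number here means a stronger inhibitor, a higher number a weaker inhibitor:
- compound 1 `COc1cc(-c2ncnn2-c2ccc(Cl)cc2)cc(OC)c1OC`: > 10000 nM (a limit of the assay, not a number)
- compound 2 `COc1ccc(-n2ncnc2-c2cc(OC)c(OC)c(OC)c2)cc1`: 7400 nM

In this assay, going by the values given here, compound 2 gives 7400 nM, the only actual number so far. Compound 1 has only a limit, > 10000 nM.

Compound 3 `COc1cc(-c2ncnn2-c2ccc(Cl)c(Cl)c2)cc(OC)c1OC` has not yet been measured. It differs from compound 2 as follows: 3,4-dichlorophenyl in place of 4-methoxyphenyl on an aromatic nitrogen. In words, 3,4-dichlorophenyl takes the place of 4-methoxyphenyl on an aromatic nitrogen.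

Among the compounds with values here, one measured step bears on this change: an at least 1.3-fold lower number from compound 1 to compound 2 (0.13 log units; that floor lies within the scatter). On these data alone, it is methoxy in place of chloro on an aromatic carbon, and its floor lies within the scatter, so its true size remains open. The change to compound 3 runs the opposite way, from methoxy back to chloro, and brings a second chlorine whose contribution has not been measured. A small move toward a higher number is therefore expected, possibly none beyond the scatter, and a result reported only as a limit would fit.

The estimated step is a 1.5-fold higher number from compound 2 to compound 3 (0.17 log units; within the scatter). Compound 3 is expected at 11000 nM, with an estimated range of 5000 nM to 25000 nM.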

Compound 3, half-maximal inhibitory concentration: > 10000 nM
Compound 3 ended at the assay's limit; the forecaster's own chance of this, stated with the estimate: 55%; the middle value is on the limit's open side.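

In this assay, putting 3,4-dichlorophenyl in place of 4-methoxyphenyl on the aromatic nitrogen gives an at least 1.3-fold higher number from compound 2 to compound 3 (0.13 log units; that floor lies within the scatter). The floor of that step lies within the scatter, so the change is not shown to weaken the compound, and its true size remains open. Compound 3 adds that a second chlorine at this position still leaves a limit of the assay rather than a number, and the step from compound 1 to compound 3, chloro in place of hydrogen on an aromatic carbon, cannot be read because both of its values are limits: the limit of > 10000 nM in this assay, at which 2 of the 3 values shown sit.

The compounds shown leave open whether either chlorinated compound truly differs from compound 2, which alone has an actual number, and what the contribution of the second chlorine is. They also leave open how the same position on the aromatic nitrogen would read with a 4-hydroxyphenyl, with a phenyl carrying a dimethylamino group or a carboxylic acid, or with a longer chain in place of the methoxy.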